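Extending a methyl to an ethyl on the shared core

A few compounds are considered here, and "the series" means these few. Any claim that something is new, unique, unknown or untested is made for them only; others in the source may bear on it.

Three compounds share a core that carries a pyridone-like ring bearing a benzyloxy group; they differ in the small groups on the core and in the halogen on the benzyl ring. Compound 3 `Cc1nc2ccc(-n3ccc(OCc4ccc(F)cc4)cc3=O)cc2n1C` is the starting point here. In an assay on CHO cells for displacement of a labelled ligand from melanin-concentrating hormone receptor 1 (Homo sapiens), read by scintillation counting, with a stated time of 1 h (on this read-out higher numbers stand for weaker inhibition and lower numbers for stronger inhibition), compound 3 gives 77 nM. Compound 1 `Cc1c(C2CC2)nc2cnc(-n3ccc(OCc4ccc(Cl)cc4)cc3=O)cn12` gives 44 nM in this assay, a gap from compound 3 that lies within the usual scatter of repeated measurements. Compound 2 `Cn1c(C2CC2)nc2ccc(-n3ccc(OCc4ccc(Cl)cc4)cc3=O)cc21` gives 35 nM in this assay, a gap from compound 3 that lies beyond that scatter.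

Compound 4 `CCc1nc2ccc(-n3ccc(OCc4ccc(F)cc4)cc3=O)cc2n1C` is not yet measured. It differs from compound 3 by one change: methyl in place of hydrogen on a saturated chain carbon bound to an aromatic carbon. Going by the values given here, no measured pair shows this change, so the expected step rests only on its small size. A change of this kind is expected to give no step beyond the scatter in this assay, in either direction. For compound 4 the expected value is 65 nM, within a range from 25 nM to 170 nM. The estimated step is a 1.2-fold lower number from compound 3 to compound 4 (0.07 log units; within the scatter).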

Compound 4, half-maximal inhibitory concentration: 48 nM
Compound 4: middle estimate off by 1.4-fold (0.13 log units), on the high side, and the stated range covers the measured number.
By their numbers in this assay, from the lowest: compounds 2, 1, 4 and 3 (each within the scatter of the next, the first and the last beyond it).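

In this assay, the change from methyl to ethyl gives a 1.6-fold lower number from compound 3 to compound 4 (0.21 log units; within the scatter). This is the first pair shown that differs in only one place, so it gives the first direct reading of this position: adding one methyl on a saturated chain carbon bound to an aromatic carbon leaves the two compounds indistinguishable on this read-out. Nothing available explains this result.

The compounds shown leave open how this position would respond to a longer chain such as propyl, or to a different kind of group such as an amine or a carboxylic acid. A single pair also cannot show whether the methyl to ethyl change would give a similar step on a compound with a chlorine on the benzyl ring.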